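From compound 3 to compound 4: a pyrazole swap

The source may report more compounds than this note shows. Statements on the series, on what has been measured and on what is new or still open speak of the compounds shown alone.

Measured in an ADME assay on BaF3 cells (Mus musculus) for inhibition, read by CellTiter-Glo, with a stated time of 72 h; a lower number here means a stronger inhibitor of growth, a higher number a weaker inhibitor of growth:
- compound 1 `Cc1cc(Nc2ncc3c(n2)N(C)C(=O)N(c2cc(NC(=O)c4ccc(CN5CCC(N(C)C)C5)c(C(F)(F)F)c4)ccc2C)C3)n(C)n1`: 509 nM
- compound 2 `Cc1ccc(NC(=O)c2cccc(C(F)(F)F)c2)cc1N1Cc2cnc(NC3CC3)nc2N(C)C1=O`: 5060 nM
- compound 3 `Cc1ccc(NC(=O)c2cccc(C(F)(F)F)c2)cc1N1Cc2cnc(Nc3cnn(C)c3)nc2N(C)C1=O`: 352 nM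

Compound 3 lies within the usual scatter of compound 1, and its number is far lower than that of compound 2. The next structure, compound 4 `Cc1cc(Nc2ncc3c(n2)N(C)C(=O)N(c2cc(NC(=O)c4cccc(C(F)(F)F)c4)ccc2C)C3)n(C)n1`, changes one group on compound 3: 1,3-dimethyl-1H-pyrazol-5-yl in place of 1-methyl-1H-pyrazol-4-yl on a nitrogen on an aromatic ring. Both groups are five-membered aromatic rings, attached on the same nitrogen.

Among the measured compounds shown here, one measured step touches this place: a 14-fold lower number from compound 2 to compound 3 (1.16 log units; beyond the scatter). That large step replaced cyclopropyl with a pyrazole, whereas here one pyrazole replaces another, so a much smaller step seems likely. Compound 1 already carries the entering 1,3-dimethyl-1H-pyrazol-5-yl group and gives 509 nM, though it also differs from compound 4 elsewhere. A slightly higher number in this assay is therefore expected, probably not beyond the scatter. The expected change is a 1.7-fold higher number from compound 3 to compound 4 (0.23 log units; within the scatter). For compound 4 the estimated value is 600 nM, with an expected range from 200 nM to 2000 nM.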

Compound 4, concentration for 50% growth inhibition: 2060 nM
Compound 4: the middle estimate sits 3.4-fold (0.54 log units) below what was measured, outside the stated range (above it).
By their numbers in this assay, from the lowest: compounds 3 and 1 (each within the scatter of the next); then compound 4; then compound 2.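

In this assay, putting 1,3-dimethyl-1H-pyrazol-5-yl in place of 1-methyl-1H-pyrazol-4-yl gives a 5.9-fold higher number from compound 3 to compound 4 (0.77 log units; beyond the scatter), so which pyrazole sits on this nitrogen matters, not only that a pyrazole is there. The entering pyrazole still compares well with cyclopropyl, with a 2.5-fold lower number from compound 2 to compound 4 (0.39 log units; beyond the scatter), but that step is smaller than a 14-fold lower number from compound 2 to compound 3 (1.16 log units; beyond the scatter). The (3-(dimethylamino)pyrrolidin-1-yl)methyl group also counts when this pyrazole is present, as hydrogen in its place gives a 4.0-fold higher number from compound 1 to compound 4 (0.61 log units; beyond the scatter), and no measurement here accounts for any of these steps.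

The compounds shown do not separate the added methyl from the changed attachment of the pyrazole. Also open, as far as these compounds go, is how a pyridine ring on this nitrogen would compare, and whether the (3-(dimethylamino)pyrrolidin-1-yl)methyl group would have the same effect alongside 1-methyl-1H-pyrazol-4-yl.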